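A few compounds are considered here, and "the series" means these few. Any claim that something is new, unique, unknown or untested is made for them only; others in the source may bear on it.

Measured so far:
- compound 1, `CC1=CC[C@H](C(C)(C)NC(=S)N/N=C/c2ccccc2)CC1`: 71400 nM
- compound 2, `CC1=CC[C@H](C(C)(C)NC(=S)N/N=C/c2ccccc2O)CC1`: 10600 nM
- compound 3, `CC1=CC[C@H](C(C)(C)NC(=S)N/N=C/c2ccccc2Cl)CC1`: > 100000 nM

In a functional assay on U-251 cells (Homo sapiens) for inhibition, read by sulforhodamine B assay, with a stated time of 48 h (a higher number here means a weaker inhibitor of growth, a lower number a stronger inhibitor of growth), compound 1 gives 71400 nM. Compound 2 gives 10600 nM in this assay. For compound 3 this assay reports only a limit, > 100000 nM, and not a number. Compound 3 therefore stands at the weak end of the three: the step of an at least 1.4-fold higher number from compound 1 to compound 3 (0.14 log units; that floor lies within the scatter) has a floor within the scatter, while the step of an at least 9.4-fold higher number from compound 2 to compound 3 (0.97 log units; beyond the scatter) is clearly beyond it. Among the compounds with values here, the one change that did move the number was hydroxy entering, a 6.7-fold lower number from compound 1 to compound 2 (0.83 log units; beyond the scatter).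

Compound 4, `CC1=CC[C@H](C(C)(C)NC(=S)N/N=C/c2ccccc2[N+](=O)[O-])CC1`, differs from compound 3 in one place: nitro in place of chloro on an aromatic carbon. Within the data shown here, no measured step involves nitro, so the only guide is that neither hydrogen nor chloro in that place gave a strong inhibitor. Compound 4 is therefore expected to stay close to compound 3, with the step of a number no higher from compound 3 to compound 4 (the limit leaves the size open) meaning no change beyond the scatter. The estimate for compound 4 in this assay is 100000 nM, between 30000 nM and 300000 nM, with a fair chance that only a limit is reported again.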

Compound 4, concentration for total growth inhibition: > 100000 nM
Compound 4: a limit, no number; the forecaster's own chance of this, stated with the estimate: 55%; the middle value sits exactly at the limit.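

In this assay, the value for compound 4 is a limit and not a number, as it is for compound 3, so two different groups in this place now end at the same limit: the limit of > 100000 nM in this assay, at which 2 of the 4 values shown sit. Hydroxy remains the only group here that gives a clearly lower number than hydrogen, and replacing it with nitro gives an at least 9.4-fold higher number from compound 2 to compound 4 (0.97 log units; beyond the scatter). Against plain hydrogen the result is an at least 1.4-fold higher number from compound 1 to compound 4 (0.14 log units; that floor lies within the scatter), so nitro cannot be ranked against hydrogen, and the step between compound 3 and compound 4 cannot be read, as both values are limits.

The compounds shown leave open whether an amine or a carboxylic acid in this place would lower the number as hydroxy does. On these data alone, how far compound 3 and compound 4 actually lie past their limit also stays unknown.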